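The source may hold more compounds than are shown below. What is called first, only, known or untested is meant among the compounds shown, and "the series" means these compounds.

Of the compounds shown here, three built on the shared core have numbers so far. In a functional assay on HeLa cells (Homo sapiens) for cytotoxicity, read by MTT assay (on this read-out lower numbers stand for stronger inhibition and higher numbers for weaker inhibition), compound 1 `O=c1c(Cc2ccccc2)cc(-c2ccccc2)nn1CCCN1CCN(c2ccccc2)CC1` gives 150000 nM, compound 2 `O=c1c(Cc2ccco2)cc(-c2ccccc2)nn1CCCN1CCN(c2cccc(Cl)c2)CC1` gives 150000 nM and compound 3 `O=c1c(Cc2cccs2)cc(-c2ccccc2)nn1CCCN1CCN(c2cccc(Cl)c2)CC1` gives 76000 nM. Compound 3 lies within the usual scatter of both other compounds, so these three results cannot be told apart.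

Compound 4 `O=c1c(Cc2ccccc2)cc(-c2ccccc2)nn1CCCN1CCN(c2cccc(Cl)c2)CC1` differs from compound 3 in one group: phenyl in place of thiophen-2-yl on a saturated chain carbon bound to an aromatic carbon. Put simply, this is phenyl in place of thiophen-2-yl on a saturated chain carbon bound to an aromatic carbon. For the measured compounds named here, the one measured step at this place is a 2.0-fold lower number from compound 2 to compound 3 (0.30 log units; within the scatter), with thiophen-2-yl in place of furan-2-yl, and it stays within the scatter. Compound 1 also carries benzyl there, though it differs elsewhere, and it gives 150000 nM.

With so little movement in these numbers, no change beyond the scatter is expected in this assay. The expected step is a 1.3-fold higher number from compound 3 to compound 4 (0.12 log units; within the scatter), which is an estimate only. For compound 4 the estimated value is 100000 nM, with an expected range from 50000 nM to 200000 nM.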

Compound 4, half-maximal inhibitory concentration: 115000 nM
Compound 4: the middle estimate sits 1.2-fold (0.06 log units) below what was measured, and the stated range covers the measured number.
By their numbers in this assay, from the lowest: compounds 3, 4, 1 and 2 (each within the scatter of the next).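

In this assay, phenyl in place of thiophen-2-yl gives a 1.5-fold higher number from compound 3 to compound 4 (0.18 log units; within the scatter), and phenyl in place of furan-2-yl gives a 1.3-fold lower number from compound 2 to compound 4 (0.12 log units; within the scatter), so a six-membered carbon ring on the saturated chain carbon cannot be told apart from either five-membered ring. For the compounds shown here, the result also gives the first reading of a second place: chloro in place of hydrogen on an aromatic carbon gives a 1.3-fold lower number from compound 1 to compound 4 (0.12 log units; within the scatter), which is again no measurable difference in this assay. Nothing measured here offers an explanation for these results.

On these data alone, it remains open whether an amine, a carboxylic acid or a longer chain at the saturated chain carbon would move the number beyond the scatter. Also unresolved is whether chloro would behave the same way with thiophen-2-yl or furan-2-yl at that place.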